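This account rests on a few compounds, and the source may have more. Where it says the series, first, only, none or still open, it means among the compounds named here.

In a functional assay on MCF7 cells (Homo sapiens) for inhibition, read by MTT assay, with stated times of 18 h and 4 h (a higher number here means a weaker inhibitor, a lower number a stronger inhibitor), the measured compounds are these

compound 1 `CCCCCCCCOP(=O)(O)OCCSC(=S)N1CCCC1` gives 53000 nM
compound 2 `CCCCCCCCOP(=O)(O)OCCSC(=S)N1CCCCC1` gives 26000 nM

Compound 2 has the lower number of the pair and so is the stronger inhibitor of the two. Among the measured compounds shown here, the only measured step, a 2.0-fold lower number from compound 1 to compound 2 (0.31 log units; beyond the scatter), came with piperidin-1-yl in place of pyrrolidin-1-yl on a thiocarbonyl carbon, and it is modest.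

Compound 3 `CCCCCCOP(=O)(O)OCCSC(=S)N1CCCCC1` keeps that piperidin-1-yl group and changes the chain instead: hydrogen in place of ethyl on a saturated chain carbon, six bonds along the chain from an oxygen on an unsaturated carbon. For the measured compounds named here, no measured step touches this chain, so the evidence is indirect. Going by the values given here, the sole guide is a 2.0-fold lower number from compound 1 to compound 2 (0.31 log units; beyond the scatter), made elsewhere in the molecule, where the larger group went with the lower number. On that thin basis, a similarly modest move toward a higher number is expected in this assay, although a change within the scatter cannot be ruled out. The expected step is a 1.9-fold higher number from compound 2 to compound 3 (0.28 log units; within the scatter). For compound 3 the estimated value is 50000 nM, with an expected range of 22000 nM to 110000 nM.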

Compound 3, half-maximal inhibitory concentration: 62000 nM
Compound 3: the middle estimate sits 1.2-fold (0.09 log units) below what was measured; low and high end bracket the measured number.
By their numbers in this assay, from the lowest: compound 2; then compounds 1 and 3 (each within the scatter of the next).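

In this assay the chain now has a measured step of its own: a 2.4-fold higher number from compound 2 to compound 3 (0.38 log units; beyond the scatter), with hydrogen in place of ethyl on a saturated chain carbon, six bonds along the chain from an oxygen on an unsaturated carbon. The earlier pair varied only the group on the thiocarbonyl carbon, so it could not show that this chain position also bears on the number; here, with piperidin-1-yl held fixed, losing the ethyl goes with a weaker inhibitor, by a step that is modest, like a 2.0-fold lower number from compound 1 to compound 2 (0.31 log units; beyond the scatter). The data given offer no account of why the number moves with this change.

This single step cannot show how the number follows chain length, whether a longer chain would lower it further or whether a polar end group such as an amine or a carboxylic acid on the chain would be tolerated. Also open, on these data alone, is whether the same shortening would act alike with pyrrolidin-1-yl on the thiocarbonyl carbon, and how a morpholin-4-yl group there would compare.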